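The compounds below may be only part of what the source reports. "The series", "measured", "known", "first", "only" and "open" are said of these compounds alone.

Of the compounds shown here, three built on one shared core have been measured in a functional assay on PC-3 cells (Homo sapiens) for cytotoxicity, read by MTT assay, with a stated time of 48 h; on this read-out lower numbers stand for stronger inhibition and higher numbers for weaker inhibition. Compound 1 `COc1cc(-c2nnc3n2NC(c2ccco2)C(C(=O)c2ccc(Cl)cc2)S3)cc(OC)c1OC` gives 67800 nM. Compound 2 `COc1cc(-c2nnc3n2NC(c2ccco2)C(C(=O)c2ccc(F)cc2)S3)cc(OC)c1OC` gives 27700 nM, and compound 3 `COc1cc(-c2nnc3n2NC(c2ccco2)C(C(=O)c2ccc(C(F)(F)F)cc2)S3)cc(OC)c1OC` gives 77500 nM. Compound 3 thus shows the highest number of the three: the step of a 1.1-fold higher number from compound 1 to compound 3 (0.06 log units; within the scatter) lies within the scatter, while the step of a 2.8-fold higher number from compound 2 to compound 3 (0.45 log units; beyond the scatter) lies beyond it. A fourth compound, compound 4 `COc1cc(-c2nnc3n2NC(c2ccco2)C(C(=O)c2ccc([N+](=O)[O-])cc2)S3)cc(OC)c1OC`, has not yet been measured. It differs from compound 3 by nitro in place of trifluoromethyl on an aromatic carbon. The measured steps that bear on this same position are a 2.4-fold lower number from compound 1 to compound 2 (0.39 log units; beyond the scatter), a 1.1-fold higher number from compound 1 to compound 3 (0.06 log units; within the scatter) and a 2.8-fold higher number from compound 2 to compound 3 (0.45 log units; beyond the scatter); together they span only a modest range, and none of them involves a nitro group, so no direct guide exists for this particular exchange. The expectation for compound 4 in this assay is therefore a number close to the others, with a step of a 1.4-fold lower number from compound 3 to compound 4 (0.15 log units; within the scatter) that may well fall within the scatter in either direction. Compound 4 is estimated at 55000 nM, with a range from 20000 nM to 150000 nM.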

Compound 4, half-maximal inhibitory concentration: 27900 nM
Compound 4: the middle estimate sits 2.0-fold (0.29 log units) above what was measured, and the stated range covers the measured number.
By their numbers in this assay, from the lowest: compounds 2 and 4 (each within the scatter of the next); then compounds 1 and 3 (each within the scatter of the next).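

In this assay the nitro group does not behave like trifluoromethyl or chloro: a 2.8-fold lower number from compound 3 to compound 4 (0.44 log units; beyond the scatter) and a 2.4-fold lower number from compound 1 to compound 4 (0.39 log units; beyond the scatter) are both modest steps, and a 1.0-fold higher number from compound 2 to compound 4 (0.00 log units; within the scatter) places nitro level with fluoro. The four groups on this aromatic carbon therefore fall into two pairs, nitro with fluoro and chloro with trifluoromethyl, and the new group does not widen the range of values already seen. Nothing measured here accounts for this pairing.

From the compounds shown here alone, whether the two pairs persist with other groups at this place, such as an amine or a carboxylic acid, remains open. So does whether a bare phenyl ring, with no group on this carbon, would sit with either pair.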